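From pyridin-4-yl to thiophen-3-yl on a carbonyl carbon

A few compounds are considered here, and "the series" means these few. Any claim that something is new, unique, unknown or untested is made for them only; others in the source may bear on it.

Of the compounds shown here, three with a shared core have been measured in a physicochemical assay for solubility, read by HPLC, with a stated time of 24 h; on this read-out higher numbers stand for higher solubility and lower numbers for lower solubility. Compound 1 `CC(C)(C)c1[nH]cnc1/C=c1\[nH]c(=O)/c(=C/c2cccc(C(=O)N3CCCC3)c2)[nH]c1=O`, which carries pyrrolidin-1-yl on the carbonyl carbon, gives 0.454 ug/mL. Compound 2 `CC(C)(C)c1[nH]cnc1/C=c1\[nH]c(=O)/c(=C/c2cccc(C(=O)c3cccnc3)c2)[nH]c1=O` gives < 0.1 ug/mL, which is a limit and not a number. Compound 3 `CC(C)(C)c1[nH]cnc1/C=c1\[nH]c(=O)/c(=C/c2cccc(C(=O)c3ccncc3)c2)[nH]c1=O` gives < 0.1 ug/mL, which is also a limit. This places compound 3 at the limit of < 0.1 ug/mL in this assay, at which 2 of the 3 values shown sit.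

Compound 4 `CC(C)(C)c1[nH]cnc1/C=c1\[nH]c(=O)/c(=C/c2cccc(C(=O)c3ccsc3)c2)[nH]c1=O` has thiophen-3-yl in place of the pyridin-4-yl of compound 3, on a carbonyl carbon: thiophen-3-yl in place of pyridin-4-yl on a carbonyl carbon. Two measured steps give a size, an at least 4.5-fold lower number from compound 1 to compound 2 (0.65 log units; beyond the scatter) and an at least 4.5-fold lower number from compound 1 to compound 3 (0.65 log units; beyond the scatter). Both put an aromatic ring in place of pyrrolidin-1-yl, and both lie beyond the scatter. The exchange closest in kind, one aromatic ring for another, is a step that the two limits leave unreadable from compound 2 to compound 3, so it gives no size to carry over. Compound 4 keeps an aromatic ring on the carbonyl carbon, so the drop seen in an at least 4.5-fold lower number from compound 1 to compound 3 (0.65 log units; beyond the scatter) is expected to remain, with no further step beyond the scatter in this assay. The expected change is a step that the limit leaves unreadable from compound 3 to compound 4. For compound 4 the estimated value is 0.07 ug/mL, with an expected range of 0.02 ug/mL to 0.2 ug/mL.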

Compound 4, solubility: < 0.1 ug/mL
Compound 4: only a limit was reported; the forecaster's own chance of this, stated with the estimate: 75%; the middle value is on the limit's open side.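

In this assay, the step to thiophen-3-yl on the carbonyl carbon reads as an at least 4.5-fold lower number from compound 1 to compound 4 (0.65 log units; beyond the scatter), so a five-membered aromatic ring with sulfur falls on the same side of compound 1 as the two six-membered aromatic rings with nitrogen. The steps among compound 2, compound 3 and compound 4 cannot be read, as all three compounds stand at a limit, so changing the ring size and the hetero atom gives no measurable difference here. All three aromatic rings shown on this carbonyl carbon now end at the same limit of the assay: the limit of < 0.1 ug/mL in this assay, at which 3 of the 4 values shown sit.

As far as these compounds go, how far compound 2, compound 3 and compound 4 lie under that limit remains open, so no order can be given among pyridin-3-yl, pyridin-4-yl and thiophen-3-yl. Also open, from the compounds shown here alone, is whether another amine on the carbonyl carbon, such as morpholin-4-yl or dimethylamino, would come close to the value of compound 1, 0.454 ug/mL in this assay, or whether that value belongs to pyrrolidin-1-yl alone.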